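From aminomethyl to 1-aminocyclopropyl on compound 2

This account rests on a few compounds, and the source may have more. Where it says the series, first, only, none or still open, it means among the compounds named here.

For the measured compounds named here, in a physicochemical assay for solubility, at pH 7.4 (a higher number here means a more soluble compound, a lower number a less soluble compound), compound 2 `Cc1c2c(n3c1CCN(C(=O)CN)C[C@@H](C)[C@H](C)Nc1cc-3ccc1C(N)=O)CC(C)(C)CC2=O` gives 46 ug/mL as the only exact number so far. Compound 1 `Cc1c2c(n3c1CCN(C(=O)[C@H](C)N)CC[C@H](C)Nc1cc-3ccc1C(N)=O)CC(C)(C)CC2=O` shows > 100 ug/mL as a limit, not a number. Compound 3 `Cc1c2c(n3c1CCN(C(=O)[C@@H](N)C(C)C)C[C@@H](C)[C@H](C)Nc1cc-3ccc1C(N)=O)CC(C)(C)CC2=O` shows > 100 ug/mL as a limit too.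

Compound 4 `Cc1c2c(n3c1CCN(C(=O)C1(N)CC1)C[C@@H](C)[C@H](C)Nc1cc-3ccc1C(N)=O)CC(C)(C)CC2=O` differs from compound 2 in one place, with 1-aminocyclopropyl in place of aminomethyl on a carbonyl carbon as the change. Going by the values given here, one measured step bears on this. Isopropyl in place of hydrogen on a saturated chain carbon bound to an amine nitrogen and a carbonyl carbon gives an at least 2.1-fold higher number from compound 2 to compound 3 (0.33 log units; beyond the scatter) as its result. That size is only a floor, set by the limit of > 100 ug/mL in this assay, at which 2 of the 3 values shown sit, in this assay as the ceiling of the readings. Both changes add carbon to the same part of compound 2, so a rise in the same direction seems likely, though a three-membered ring is not an open chain. The expected change is a 2.2-fold higher number from compound 2 to compound 4 (0.34 log units; beyond the scatter) in this assay as a modest rise. For compound 4 the estimate is 100 ug/mL with an expected range from 45 ug/mL to 220 ug/mL as its spread.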

Compound 4, solubility: 7 ug/mL
Compound 4: the middle estimate sits 14-fold (1.15 log units) above what was measured; measured number below the stated range.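

This result shows that adding carbon to the group on this carbonyl carbon does not fix the direction of the change in this assay. The earlier step to compound 3 went up, whereas the 1-aminocyclopropyl group gives a 6.6-fold lower number from compound 2 to compound 4 (0.82 log units; beyond the scatter). Setting the two new groups against each other, 1-aminocyclopropyl in place of 1-amino-2-methylpropyl gives an at least 14-fold lower number from compound 3 to compound 4 (1.15 log units; beyond the scatter), and that size is only a floor, set by a limit: the limit of > 100 ug/mL in this assay, at which 2 of the 4 values shown sit.

The compounds shown leave open whether the fall belongs to the three-membered ring itself, or would also come with an open group such as 1-amino-1-methylethyl or a larger ring such as 1-aminocyclobutyl on the same carbonyl carbon. From the compounds shown here alone, how far compound 3 truly stands from compound 4 also remains unknown.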